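Shortening the Ester Chain: Isopropyl to Methyl

The source may hold more compounds than are shown below. What is called first, only, known or untested is meant among the compounds shown, and "the series" means these compounds.

Compound 1 `CC(C)OC(=O)N1CCC(Oc2ncnc3c2CCN3c2ccc(S(C)(=O)=O)cc2F)CC1` gives 50.1 nM in a functional assay on CHO-K1 cells for agonist activity at Glucose-dependent insulinotropic receptor (Homo sapiens), read by a luciferase reporter, with a stated time of 5 h (a higher number here means that more compound is needed for the effect, a lower number that less compound is needed), the lowest of the three numbers measured. Compound 3 `CC(C)OC(=O)N1CCC(Oc2ncnc3c2CCN3c2ccc(-c3nccs3)cc2F)CC1` gives 79.4 nM, and compound 2 `CC(C)OC(=O)N1CCC(Oc2ncnc3c2CCN3c2ccc(S(C)(=O)=O)cc2)CC1` gives 126 nM. The step of a 1.6-fold higher number from compound 1 to compound 3 (0.20 log units; within the scatter) lies within the scatter, whereas a 2.5-fold higher number from compound 1 to compound 2 (0.40 log units; beyond the scatter) is beyond it, so compound 1 is set apart from compound 2 but not from compound 3.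

Compound 4 `COC(=O)N1CCC(Oc2ncnc3c2CCN3c2ccc(S(C)(=O)=O)cc2F)CC1` differs from compound 1 by methyl in place of isopropyl on an oxygen next to a carbonyl group. Neither measured step touches this part of the molecule: both alter the aromatic ring, not the group on the oxygen next to the carbonyl. The two measured steps show that single small changes in this series moved the number by modest amounts at most. With nothing bearing directly on the carbonyl side, a modest step in this assay is expected, more likely towards a higher number, but it may well stay within the scatter. Compound 4 is therefore estimated at 80 nM, with a range from 30 nM to 250 nM, a step of a 1.6-fold higher number from compound 1 to compound 4 (0.20 log units; within the scatter).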

Compound 4, half-maximal effective concentration: 316 nM
Compound 4: middle estimate off by 4.0-fold (0.60 log units), on the low side; measured number outside the range, above it.
By their numbers in this assay, from the lowest: compounds 1, 3 and 2 (each within the scatter of the next, the first and the last beyond it); then compound 4.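

In this assay the change from isopropyl to methyl on an oxygen next to a carbonyl group produces a 6.3-fold higher number from compound 1 to compound 4 (0.80 log units; beyond the scatter) and so shows that this side of the molecule also affects the number, which the changes on the aromatic ring could not show. That step is larger than either aromatic change, a 2.5-fold higher number from compound 1 to compound 2 (0.40 log units; beyond the scatter) and a 1.6-fold higher number from compound 1 to compound 3 (0.20 log units; within the scatter), making it the largest of the three steps from compound 1. No measurement shown here accounts for the higher number with the shorter group.

The compounds shown leave open how ethyl or tert-butyl would read on this oxygen, and whether a longer chain would lower the number further. From the compounds shown here alone, whether methyl has the same effect alongside the 1,3-thiazol-2-yl group of compound 3 also remains open.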